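Swapping the Aryl Group on the Shared Core

The source may report more compounds than this note shows. Statements on the series, on what has been measured and on what is new or still open speak of the compounds shown alone.

In a functional assay on U-87MG ATCC cells for antiproliferative activity against U-87 MG (Homo sapiens), read by MTT assay, with a stated time of 72 h (on this read-out higher numbers stand for weaker inhibition and lower numbers for stronger inhibition), compound 1 `CNC(=O)c1cc(Oc2ccc(NC(=O)c3cc4cccnc4n(-c4ccc(F)cc4)c3=O)cc2)ccn1` gives 2910 nM, while compound 3 `CCCNC(=O)c1cc(Oc2ccc(NC(=O)c3cc4cccnc4n(-c4ccc(F)cc4)c3=O)cc2)ccn1` gives 960 nM, the lowest of the two numbers shown; the single measured step, a 3.0-fold lower number from compound 1 to compound 3 (0.48 log units; beyond the scatter), concerns the amide chain, not the aryl group. Compound 2 `CCNC(=O)c1cc(Oc2ccc(NC(=O)c3cc4cccnc4n(-c4ccc(C(F)(F)F)cc4Cl)c3=O)cc2)ccn1` gives "not determined" (no result reported) in this assay. Compound 4 `CCCNC(=O)c1cc(Oc2ccc(NC(=O)c3cc4cccnc4n(-c4ccc(C(F)(F)F)cc4Cl)c3=O)cc2)ccn1` differs from compound 3 by 2-chloro-4-(trifluoromethyl)phenyl in place of 4-fluorophenyl on an aromatic nitrogen. Within the data shown here, no measured step touches this position: compound 2 carries the same entering group but reports no number, so the data give no guide to how this change moves the result. The expectation for compound 4 is therefore a 1.0-fold higher number from compound 3 to compound 4 (0.02 log units; within the scatter), no shift beyond the scatter, with a broad range. Compound 4 is thus estimated at 1000 nM, between 250 nM and 4000 nM.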

Compound 4, half-maximal inhibitory concentration: 10900 nM
Compound 4: the middle estimate sits 11-fold (1.04 log units) below what was measured; the measured number lies above the stated range.
By their numbers in this assay, from the lowest: compound 3; then compound 1; then compound 4.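

At this position on an aromatic nitrogen, the aryl group clearly matters: in this assay, 2-chloro-4-(trifluoromethyl)phenyl in place of 4-fluorophenyl gives an 11-fold higher number from compound 3 to compound 4 (1.06 log units; beyond the scatter) and so moves the result towards weaker inhibition. Among these compounds, this is the first measured change at this position, and it reverses the gain seen at the amide chain in compound 3. Nothing available explains the shift.

As far as these compounds go, the chlorine and the trifluoromethyl enter together, so which of them drives the step remains open. A plain phenyl, 2-chlorophenyl or 4-(trifluoromethyl)phenyl group could separate them.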